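A few compounds are considered here, and "the series" means these few. Any claim that something is new, unique, unknown or untested is made for them only; others in the source may bear on it.

Compound 2 `Cn1cc(-c2cnc3c(-c4csc(C(=O)N[C@@H]5CCCC[C@@H]5N)c4)cnn3c2)cn1` carries a 2-aminocyclohexyl group on the amide nitrogen of the shared core. In an assay for inhibition of MAP/microtubule affinity-regulating kinase 3 (Homo sapiens), read by HTRF, with a stated time of 2 h (a lower number here means a stronger inhibitor, a higher number a weaker inhibitor), compound 2 stands at <= 0.5 nM, which is a limit of the assay rather than a number. Compound 1 `Cn1cc(-c2cnc3c(-c4csc(C(=O)N[C@@H]5CCC[C@H]5O)c4)cnn3c2)cn1` bears 2-hydroxycyclopentyl at the same position, and in this assay compound 1 gives 10 nM. Among the measured compounds shown here, the only measured step is an at least 20-fold lower number from compound 1 to compound 2 (1.30 log units; beyond the scatter); one of its two values sits at the limit of <= 0.5 nM in this assay, at which 1 of the 2 values shown sits, so the true size of that step is not fixed. Compound 3 `Cc1sc(C(=O)N[C@@H]2CCCC[C@@H]2N)cc1-c1cnn2cc(-c3cnn(C)c3)cnc12` differs from compound 2 by methyl in place of hydrogen on an aromatic carbon. For the measured compounds named here, no measured step touches that aromatic position, so there is no direct guide. The step is expected to be an at least 1.2-fold higher number from compound 2 to compound 3 (0.07 log units; that floor lies within the scatter), within the scatter. Compound 3 is therefore estimated at 0.6 nM, with a range from 0.2 nM to 3 nM, and a fair chance that again only a limit is reported.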

Compound 3, half-maximal inhibitory concentration in the MAP/microtubule affinity-regulating kinase 3 assay: 1.3 nM
For compound 3 the middle estimate is 2.2-fold (0.34 log units) below the measured one, and the stated range covers the measured number.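

The methyl on the aromatic carbon next to the ring sulfur is the only change shown at this position, and in the MAP/microtubule affinity-regulating kinase 3 assay it gives an at least 2.6-fold higher number from compound 2 to compound 3 (0.41 log units; beyond the scatter), so this carbon does respond to substitution, and the response is a weaker inhibitor. Compound 2 stands at a limit rather than a number, so that step gives only a floor: the limit of <= 0.5 nM in the MAP/microtubule affinity-regulating kinase 3 assay, at which 1 of the 3 values shown sits. In a physicochemical assay for solubility, at pH 7 (a lower number here means a less soluble compound, a higher number a more soluble compound), compound 2 gives 68000 nM and compound 3 gives 192000 nM. The same methyl thus goes with a more soluble compound, so the change loses in one read-out and gains in the other: the measured solubility of compound 2, 68000 nM, and of compound 3, 192000 nM, a 2.8-fold higher number (0.45 log units; beyond the scatter).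

On these data alone, whether chlorine, ethyl or methoxy at this aromatic carbon would shift the two read-outs in the same way remains open. Also open, as far as these compounds go, is whether methyl here would have the same effect alongside the 2-hydroxycyclopentyl amide of compound 1.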